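A few compounds are considered here, and "the series" means these few. Any claim that something is new, unique, unknown or untested is made for them only; others in the source may bear on it.

Measured in a functional assay on HCT-116 cells (Homo sapiens) for inhibition, read by CCK-8 assay, with a stated time of 72 h, tested at 8 uM (a higher number here means more inhibition of growth at the concentration tested, a lower number less inhibition of growth), so far:

- Compound 1 `Nc1ccccc1NC(=O)c1ccc(CSc2ccc(Br)cc2)cc1` gives 67.7%
- Compound 2 `Nc1ccccc1NC(=O)/C=C/c1ccc(CSc2cccc3ccccc23)cc1` gives 35.2%

Compound 1 holds the higher of these two numbers. The gap from compound 1 to compound 2 lies beyond the usual scatter of such measurements. With only two results, that ranking says little about what drives growth inhibition in these cells.

The next compound to be tested is compound 3 `Nc1ccccc1NC(=O)c1ccc(CSc2ccc(Cl)cc2)cc1`. It comes from compound 1 through a single change at the end of the molecule: chloro in place of bromo on an aromatic carbon. In words, chloro takes the place of bromo on an aromatic carbon, so 4-bromophenyl becomes 4-chlorophenyl, and the rest of the structure stays as it is.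

Among the measured compounds shown here, no measured pair of compounds differs in only one place, so the data give no direct measure of this swap. The expectation in this assay is therefore no step beyond the scatter, in either direction, and compound 1 at 67.7% serves as the anchor. The expected result is a number 2.7 percentage points lower from compound 1 to compound 3 (within the scatter). For compound 3 the estimated value is 65%, with an expected range from 50% to 78%.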

Compound 3, percent growth inhibition at one concentration: 76.6%
Compound 3: the middle estimate sits 11.6 percentage points below what was measured, within the range that was stated.
By their numbers in this assay, from the lowest: compound 2; then compounds 1 and 3 (each within the scatter of the next).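

Chloro in place of bromo on this aromatic carbon, para to a large group, gives a number 8.9 percentage points higher from compound 1 to compound 3 (within the scatter) in this assay and provides the only comparison shown in which two compounds differ in one place. At this position, the result does not separate the 4-bromophenyl and 4-chlorophenyl compounds, and growth inhibition at the tested concentration remains in the same range with either halogen. Nothing shown here bears on why the two compounds read alike.

This single swap between two halogens leaves open how far the position accepts other groups, such as fluoro, methoxy, an amine or a carboxylic acid, in place of chloro or bromo. Compound 2 differs from compound 1 and compound 3 in more than one place, so its lower number cannot be assigned to any one part of its structure.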